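Trifluoromethyl for methylsulfonyl on an amide series at the limit

The compounds below may be only part of what the source reports. "The series", "measured", "known", "first", "only" and "open" are said of these compounds alone.

The series shares one core, carried by compound 1 `CS(=O)(=O)c1ccc(C(=O)Nc2ccc(Cl)c(-c3nnc4c(Cl)cccn34)c2)c(Cl)c1`, compound 2 `Cc1nc(C(=O)Nc2ccc(Cl)c(-c3nnc4c(Cl)cccn34)c2)cs1` and compound 3 `O=C(Nc1ccc(Cl)c(-c2nnc3c(Cl)cccn23)c1)c1c(F)cccc1Cl`, each an amide on that core with a different group on the carbonyl carbon. In a functional assay on MCF7 cells (Homo sapiens) for antiproliferative activity, read by MTT assay, with a stated time of 72 h (on this read-out higher numbers stand for weaker inhibition and lower numbers for stronger inhibition), compound 1 gives > 100000 nM, which is a limit of the assay and not a number. In this assay compound 2 gives > 100000 nM, again a limit. In this assay compound 3 gives > 100000 nM, also a limit. Going by the values given here, because of the limit of > 100000 nM in this assay, at which 3 of the 3 values shown sit, compound 1 cannot be placed against the others, and the one step between measured compounds, a step that the two limits leave unreadable from compound 2 to compound 3, is left without a readable size by the two limits.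

Compound 4 `O=C(Nc1ccc(Cl)c(-c2nnc3c(Cl)cccn23)c1)c1ccc(C(F)(F)F)cc1Cl` arises from compound 1 by trifluoromethyl in place of methylsulfonyl on an aromatic carbon. Among the compounds with values here, no measured step bears on this change, and the only step that exists, a step that the two limits leave unreadable from compound 2 to compound 3, gave no size to lean on. The expectation therefore rests on the limit of > 100000 nM in this assay, at which 3 of the 3 values shown sit: every value shown sits at the same limit, so compound 4 is expected to sit there as well, with a step of a number no higher from compound 1 to compound 4 (the limit leaves the size open) that is not expected to carry it beyond the scatter. The estimate for compound 4 is 100000 nM, in the range 30000 nM to 300000 nM.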

Compound 4, half-maximal inhibitory concentration: 81600 nM
Beside the measured number, compound 4's estimate is 1.2-fold (0.09 log units) above it; low and high end bracket the measured number.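

At this position, the aromatic carbon para to a large group and meta to a chloro group, the change gives the only readable number among the compounds shown: in this assay compound 4 gives 81600 nM. Trifluoromethyl in place of methylsulfonyl comes with an at least 1.2-fold lower number from compound 1 to compound 4 (0.08 log units; that floor lies within the scatter), so the data set a floor on the step and no upper bound. The true size of the step stays open because compound 1 carries a limit and not a number: the limit of > 100000 nM in this assay, at which 3 of the 4 values shown sit.

The compounds shown leave open whether the readable value of compound 4 belongs to trifluoromethyl itself or would also come with another group at this place, such as a nitrile, a methoxy group, an amine or a carboxylic acid. They also leave open whether the value of compound 4 would hold with the chloro group on the same ring replaced by hydrogen or by a methyl group.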